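Methoxy for trifluoromethyl on a cytotoxicity-inactive sulfonamide scaffold

The source may hold more compounds than are shown below. What is called first, only, known or untested is meant among the compounds shown, and "the series" means these compounds.

Compound 1 `CC1CCN(C2CCN(S(=O)(=O)c3cccc(-c4ccccc4F)c3)CC2)CC1`: > 5000 nM
Compound 2 `CC1CCN(C2CCN(S(=O)(=O)c3ccccc3-c3ccc(C(F)(F)F)cc3)CC2)CC1`: > 5000 nM
Compound 3 `CC1CCN(C2CCN(S(=O)(=O)c3cccc(C(F)(F)F)c3)CC2)CC1`: > 5000 nM

Of the compounds shown here, three have been tested in an ADME assay on HCT-116 cells (Homo sapiens) for cytotoxicity, read by CellTiter-Glo, with a stated time of 72 h; a lower number here means a stronger inhibitor, a higher number a weaker inhibitor. In this assay compound 1 reaches only a limit, > 5000 nM. Compound 2 also gives only a limit, > 5000 nM. Compound 3 likewise sits at a limit, > 5000 nM. For the measured compounds named here, the single step between measured compounds, a step that the two limits leave unreadable from compound 1 to compound 3, therefore cannot be read as a number. The unmeasured compound 4 `COc1ccc(-c2ccccc2S(=O)(=O)N2CCC(N3CCC(C)CC3)CC2)cc1` differs from compound 2 by methoxy in place of trifluoromethyl on an aromatic carbon. Going by the values given here, no measured step involves a methoxy group, so the change carries no direct precedent; what exists is the limit of > 5000 nM in this assay, at which 3 of the 3 values shown sit, the same limit shared by every compound so far. Given that compound 2 stands at that limit, compound 4 is expected to stay at it as well, with a step that the limit leaves unreadable from compound 2 to compound 4 that is not expected to cross into a measurable value. Compound 4 is estimated at 9000 nM, in the range 3000 nM to 30000 nM.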

Compound 4, half-maximal inhibitory concentration: > 5000 nM
Compound 4: no number, only a limit; the forecaster's own chance of this, stated with the estimate: 85%; the middle value does not contradict the limit.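

The step from compound 2 to compound 4, methoxy in place of trifluoromethyl, cannot be read, and no new comparison follows from it: the limit of > 5000 nM in this assay, at which 4 of the 4 values shown sit. The compounds shown leave open whether any change to the shared core would give a measurable value in this assay.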